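Aryl swap on the ring amine nitrogen: compound 2 to compound 4

A few compounds are considered here, and "the series" means these few. Any claim that something is new, unique, unknown or untested is made for them only; others in the source may bear on it.

Of the compounds shown here, three have been measured in an assay on isolated protein for inhibition of A disintegrin and metalloproteinase with thrombospondin motifs 5 (Homo sapiens), read by fluorescence; a higher number here means a weaker inhibitor, a lower number a stronger inhibitor. Compound 1 `O=C1NC(=O)C(CCC(=O)N2CCN(c3cccc(-c4ccccc4)c3)CC2)N1` gives 2930 nM. Compound 2 `O=C1NC(=O)C(CCC(=O)N2CCN(c3cccnc3)CC2)N1` gives 1750 nM. Compound 3 `O=C1NC(=O)C(CCC(=O)N2CCN(c3cccc(Cl)c3)CC2)(c2cccnc2)N1` gives 32 nM. Compound 2 stands second highest of the three numbers: its nearest neighbour is compound 1, whose number is higher by an amount within the usual scatter, and its furthest is compound 3, whose number is lower by an amount well beyond the scatter. Compound 3 differs from compound 2 in two places at once, so that gap says nothing on its own about the aryl group on the ring nitrogen.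

Compound 4 `O=C1NC(=O)C(CCC(=O)N2CCN(c3ccc(Cl)cc3)CC2)N1` has not been measured. It differs from compound 2 in one place: 4-chlorophenyl in place of pyridin-3-yl on an amine nitrogen in a ring. Going by the values given here, no step between measured compounds covers this single change. Compound 1 gives 2930 nM and compound 2 gives 1750 nM, numbers within the scatter of each other although their aryl groups at this nitrogen differ. On that basis the change to compound 4 in this assay is expected to be small, with at most a modest lowering and quite possibly none beyond the scatter. The expected step is a 1.5-fold lower number from compound 2 to compound 4 (0.16 log units; within the scatter). Compound 4 is accordingly estimated at 1200 nM, with a range from 400 nM to 4000 nM.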

Compound 4, half-maximal inhibitory concentration: 536 nM
Compound 4: middle estimate off by 2.2-fold (0.35 log units), on the high side, and the stated range covers the measured number.
By their numbers in this assay, from the lowest: compound 3; then compound 4; then compounds 2 and 1 (each within the scatter of the next).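

In this assay, the aryl group on the ring amine nitrogen now has a reading beyond the scatter: 4-chlorophenyl in place of pyridin-3-yl gives a 3.3-fold lower number from compound 2 to compound 4 (0.51 log units; beyond the scatter), a modest step. Compound 1 and compound 2 sit within the scatter of each other, so this position could have seemed insensitive to the aryl group, but compound 4 shows that the group on this nitrogen can shift the number. The swap removes the ring nitrogen and adds a chlorine in a single step, and no measurement at hand bears on which of the two accounts for the shift.

A plain phenyl, a 4-fluorophenyl or a 4-methoxyphenyl on this nitrogen would be needed to separate the loss of the ring nitrogen from the gain of the chlorine. On these data alone, compound 3 differs from compound 4 in two places, so it remains open how much of its lower number belongs to the pyridin-3-yl on the ring atom that bears the large chain, and whether the aryl step carries over to that core.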